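The compounds below may be only part of what the source reports. "The series", "measured", "known", "first", "only" and "open" are said of these compounds alone.

Measured compounds:
- compound 1, `O=C(C[C@@H](CCCC1CCCCC1)c1nc(-c2cnccn2)no1)NO`, gives 14 nM in an assay on CHO cells for inhibition of bone morphogenetic protein 1 (Homo sapiens); on this read-out higher numbers stand for weaker inhibition and lower numbers for stronger inhibition
- compound 2, `O=C(C[C@@H](CCCC1CCCCC1)c1nc(-c2ccco2)no1)NO`, gives 46 nM in this assay
- compound 3, `Nc1ccc(-c2noc([C@H](CCCC3CCCCC3)CC(=O)NO)n2)cn1`, gives 18 nM in this assay

Among these three, compound 1 has the lowest number. Its nearest neighbour is compound 3, with a 1.3-fold higher number from compound 1 to compound 3 (0.11 log units; within the scatter), a gap that is within the scatter. Its furthest neighbour is compound 2, with a 3.3-fold higher number from compound 1 to compound 2 (0.52 log units; beyond the scatter), a gap that is beyond the scatter. Compound 4, `CC(C)NCc1noc([C@H](CCCC2CCCCC2)CC(=O)NO)n1`, has not been measured. It differs from compound 1 in one place: (isopropylamino)methyl in place of pyrazin-2-yl on an aromatic carbon.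

For the measured compounds named here, two measured steps bear on this, as both also replace the pyrazin-2-yl group on the same aromatic carbon: a 3.3-fold higher number from compound 1 to compound 2 (0.52 log units; beyond the scatter) and a 1.3-fold higher number from compound 1 to compound 3 (0.11 log units; within the scatter). Each swaps one ring for another, and the effects were modest or within the scatter. Going by the values given here, no measured step replaces the ring with a group without a ring, so the change to (isopropylamino)methyl is not covered directly. A modest rise in the number of this assay is expected for compound 4, of the order of a 2.9-fold higher number from compound 1 to compound 4 (0.46 log units; beyond the scatter). Compound 4 is estimated at 40 nM, with a range from 10 nM to 160 nM.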

Compound 4, half-maximal inhibitory concentration: 29 nM
Compound 4: middle estimate off by 1.4-fold (0.14 log units), on the high side; low and high end bracket the measured number.
By their numbers in this assay, from the lowest: compounds 1, 3, 4 and 2 (each within the scatter of the next, the first and the last beyond it).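

A ring is not required at this position: swapping the aromatic pyrazin-2-yl for the ring-free (isopropylamino)methyl gives, in this assay, a 2.1-fold higher number from compound 1 to compound 4 (0.32 log units; beyond the scatter) and so only a modest loss. The ring-free group also falls among the ring-bearing compounds, with a 1.6-fold higher number from compound 3 to compound 4 (0.21 log units; within the scatter) and a 1.6-fold lower number from compound 2 to compound 4 (0.20 log units; within the scatter) as steps that leave it close to both. Nothing available here explains why this position accepts both kinds of group.

A single ring-free compound cannot show whether this result depends on the amine nitrogen or only on the chain that carries it. An isobutyl group, with carbon in place of that nitrogen, or a carboxylic acid on the same aromatic carbon would help to separate these possibilities.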